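Amidine substitution on the five-carbon linker analogue

A few compounds are considered here, and "the series" means these few. Any claim that something is new, unique, unknown or untested is made for them only; others in the source may bear on it.

Three compounds of the series carry a number in an ADME assay on L6 cells (Rattus norvegicus) for cytotoxicity, read by resazurin assay, with a stated time of 70 h; on this read-out lower numbers stand for stronger inhibition and higher numbers for weaker inhibition. Compound 1 `CC(C)NC(=N)c1ccc2oc(-c3ccc(OCCCOc4ccccc4)cc3)cc2c1` gives 45600 nM, compound 2 `CC(C)NC(=N)c1ccc2oc(-c3ccc(OCCCCOc4ccccc4)cc3)cc2c1` gives 6900 nM, and compound 3 `N=C(N)c1ccc2oc(-c3ccc(OCCCCCOc4ccccc4)cc3)cc2c1` gives 4200 nM. Compound 3 stands at the lowest of the three numbers; its gap to compound 2 lies within the scatter, while its gap to compound 1 lies beyond it. Going by the values given here, the only one-point step among the measured compounds, a 6.6-fold lower number from compound 1 to compound 2 (0.82 log units; beyond the scatter), concerns the chain between the two aromatic oxygens and not the amidine.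

Compound 4 `CC(C)NC(=N)c1ccc2oc(-c3ccc(OCCCCCOc4ccccc4)cc3)cc2c1` differs from compound 3 by isopropyl in place of hydrogen on an amine nitrogen, that is, amino to isopropylamino. Among the compounds with values here, no measured pair differs in this place alone: compounds 1 and 2 carry the isopropyl group together with shorter chains, and compound 3 carries the unsubstituted amidine with the longest chain, so the contribution of the group cannot be separated from that of the chain. The comparison of compound 2 with compound 3 combines both changes and lies within the scatter. In this assay the expected outcome is therefore a 1.2-fold lower number from compound 3 to compound 4 (0.08 log units; within the scatter), nothing beyond the scatter. The estimate for compound 4 is 3500 nM, with a range from 1500 nM to 9000 nM.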

Compound 4, half-maximal inhibitory concentration: 20500 nM
Beside the measured number, compound 4's estimate is 5.9-fold (0.77 log units) below it; measured number outside the range, above it.
By their numbers in this assay, from the lowest: compounds 3 and 2 (each within the scatter of the next); then compound 4; then compound 1.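

In this assay, going by these compounds alone, isopropyl in place of hydrogen on the amine nitrogen of the amidine carries a cost on this chain that the earlier compounds could not separate from the chain itself, with a 4.9-fold higher number from compound 3 to compound 4 (0.69 log units; beyond the scatter) as the first reading of this change alone. Among the isopropylamino compounds the number also does not move one way as the chain changes: a 6.6-fold lower number from compound 1 to compound 2 (0.82 log units; beyond the scatter) is followed by a 3.0-fold higher number from compound 2 to compound 4 (0.47 log units; beyond the scatter) while a 2.2-fold lower number from compound 1 to compound 4 (0.35 log units; beyond the scatter) remains overall, so compound 2 holds the lowest number of these three. No measured data shown here bear on the origin of either effect.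

As far as these compounds go, whether amino to isopropylamino has a similar effect on the shorter chains remains open, since this pair is available only with the chain shared by compound 3 and compound 4. Also open, from the compounds shown here alone, are the readings for smaller or larger amine substituents, such as methyl or cyclopentyl, and for isopropylamino compounds with a longer chain.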